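This account rests on a few compounds, and the source may have more. Where it says the series, first, only, none or still open, it means among the compounds named here.

Measured so far:
- compound 1 `COc1ccc(C2CC(=NOC(=O)c3cccc(Cl)c3)CC(c3ccc(OC)cc3)N2C)cc1`: 136000 nM
- compound 2 `COc1ccc(C2CC(=NOC(=O)c3ccccc3OC(C)=O)CC(c3ccc(OC)cc3)N2C)cc1`: 350000 nM

Among the measured compounds shown here, in a functional assay, with a stated time of 30 min (a higher number here means a weaker inhibitor, a lower number a stronger inhibitor), compound 2 gives the highest of the two numbers; the only neighbour, compound 1, sits lower, by a 2.6-fold higher number from compound 1 to compound 2 (0.41 log units; beyond the scatter). Compound 3 `COc1ccc(C2CC(=NOC(=O)c3cccc(O)c3)CC(c3ccc(OC)cc3)N2C)cc1` differs from compound 2 in the group on the carbonyl carbon: 3-hydroxyphenyl in place of 2-acetoxyphenyl on a carbonyl carbon. For the measured compounds named here, the single measured step that bears on this change is the swap of the aryl group on that same carbonyl, a 2.6-fold higher number from compound 1 to compound 2 (0.41 log units; beyond the scatter), a modest step. A change of similar size is therefore expected, toward a lower number, since compound 3 again carries a 3-substituted phenyl as compound 1 does. The estimated step from compound 2 to compound 3 is a 2.3-fold lower number from compound 2 to compound 3 (0.37 log units; beyond the scatter). Compound 3 is expected to give about 150000 nM, in a range from 50000 nM to 500000 nM.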

Compound 3, half-maximal inhibitory concentration: 34000 nM
Compound 3: middle estimate off by 4.4-fold (0.64 log units), on the high side; measured number below the stated range.
By their numbers in this assay, from the lowest: compound 3; then compound 1; then compound 2.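

In this assay, the group on the carbonyl carbon can shift the number much further than the first pair showed: 3-hydroxyphenyl in place of 2-acetoxyphenyl gives a 10-fold lower number from compound 2 to compound 3 (1.01 log units; beyond the scatter). Keeping the same ring placement, hydroxy in place of chloro on an aromatic carbon still gives a 4.0-fold lower number from compound 1 to compound 3 (0.60 log units; beyond the scatter), so the identity of the group matters, not only where it sits. No available evidence explains these differences.

Going by these compounds, whether an amine or a carboxylic acid in place of the hydroxy would lower the number further remains open. So does how a 2-hydroxyphenyl group would compare with compound 2 and compound 3.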